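A Chroman Acid, Its Amide Cousins, and an Amino Acid

The source may report more compounds than this note shows. Statements on the series, on what has been measured and on what is new or still open speak of the compounds shown alone.

Of the compounds shown here, three built on the same chroman core have so far been tested in an ADME assay on SH-SY5Y cells (Homo sapiens) for cytotoxicity, read by MTT assay, with a stated time of 24 h, tested at 12.5 uM; on this read-out lower numbers stand for a stronger effect and higher numbers for a weaker effect at the one concentration tested. Compound 1 `COc1cc2c(cc1O)CCC(C)(CC(=O)O)O2` carries a short acid chain and in this assay gives 92%. Compound 2 `COc1cc2c(cc1O)CCC(C)(CC(=O)N[C@@H](CCC(N)=O)C(=O)O)O2` extends that chain into an amide and gives 84.8%. Compound 3 `COc1cc2c(cc1O)CCC(C)(CCNC(=O)/C=C(C)/C=C/C=C(C)/C=C/C1=C(C)CCCC1(C)C)O2`, bearing a long unsaturated tail, gives 100%. On these numbers compound 1 sits between the other two, with both gaps inside the usual scatter of this assay, so no real separation among the three is shown.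

Compound 4 `COc1cc2c(cc1O)CCC(C)(CC(N)C(=O)O)O2` has not yet been measured. Compared with compound 1 the change is amino(carboxy)methyl in place of carboxy on a saturated chain carbon bound to a saturated ring carbon. For the measured compounds named here, no measured pair shows this exact step, so the expectation leans on the absence of any separation among compounds 1, 2 and 3 in this assay. The step from compound 1 to compound 4 is therefore expected to be a number 2 percentage points lower from compound 1 to compound 4 (within the scatter), nothing beyond the scatter. Compound 4 is estimated at 90%, within a range of 78% to 100%.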

Compound 4, a percentage reported as activity, at one concentration (the size of the read-out at that concentration, not a potency): 100%
Beside the measured number, compound 4's estimate is 10 percentage points below it; low and high end bracket the measured number.
By their numbers in this assay, from the lowest: compounds 2, 1, 3 and 4 (each within the scatter of the next, the first and the last beyond it).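

In this assay, the change from carboxymethyl to 2-amino-2-carboxyethyl gives a number 8 percentage points higher from compound 1 to compound 4 (within the scatter). This is the first single-place change shown at this position, and it adds an amine and one more carbon to the chain without moving the read-out outside the usual scatter at the one concentration tested. Nothing measured here bears on why the read-out behaves this way.

The compounds shown leave open whether a methyl ester or a primary alcohol in place of the carboxy would also stay within the scatter. They also leave open whether a longer chain carrying the same amine and carboxylic acid would do so, and whether any of these results would hold at a higher concentration.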